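Sulfonyl aryl variation on a shared core: working notes

The compounds below may be only part of what the source reports. "The series", "measured", "known", "first", "only" and "open" are said of these compounds alone.

Compound 1 `O=S(=O)(Nc1ccc(-c2nc3ccccc3o2)cc1)c1ccccc1Cl`: in an assay on cells for inhibition of HSP60/HSP10 (Homo sapiens), with a stated time of 60 min (a lower number here means a stronger inhibitor, a higher number a weaker inhibitor), compound 1 gives > 100000 nM, which is a limit of the assay and not a number.
Compound 2 `O=S(=O)(Nc1ccc(-c2nc3ccccc3o2)cc1)c1ccc(C(F)(F)F)cc1`: in this assay compound 2 gives 50000 nM.

Compound 1 stands only at a limit, as shown by the limit of > 100000 nM in this assay, at which 1 of the 2 values shown sits. Among the measured compounds shown here, no measured step joins compound 1 and compound 2; the two values show only that compound 2 has a number where compound 1 has none, and that both sit at the weak end of the scale.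

Compound 3 `COc1ccc(Cl)cc1S(=O)(=O)Nc1ccc(-c2nc3ccccc3o2)cc1` is still to be measured in this assay. It differs from compound 1 in one place: 5-chloro-2-methoxyphenyl in place of 2-chlorophenyl on a sulfonyl sulfur. Nothing measured in this set says which way such a change moves this assay. With both measured compounds weak and compound 1 at a limit, the expected step of an at least 1.2-fold lower number from compound 1 to compound 3 (0.09 log units; that floor lies within the scatter) is none beyond the scatter, with a fair chance that compound 3 also returns only a limit. Compound 3 is therefore estimated at 80000 nM, expected between 20000 nM and 300000 nM.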

Compound 3, half-maximal inhibitory concentration: > 100000 nM
Compound 3 gave a limit, no number; the forecaster's own chance of this, stated with the estimate: 55%; at least 1.2-fold (0.09 log units) between middle value and limit.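

In this assay compound 3 gives > 100000 nM, which is a limit of the assay and not a number. Compound 1 also stands at a limit, so no step between compound 1 and compound 3 can be read: the limit of > 100000 nM in this assay, at which 2 of the 3 values shown sit.

The compounds shown leave open how 5-chloro-2-methoxyphenyl and 2-chlorophenyl on a sulfonyl sulfur rank against each other in this assay.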